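Removing the ethoxycarbonyl group from compound 3

The source may hold more compounds than are shown below. What is called first, only, known or untested is meant among the compounds shown, and "the series" means these compounds.

Compound 1 `Nc1n[nH]c(N)c1/N=N/c1ccncc1`: 17000 nM
Compound 2 `Nc1nn(C(=O)c2ccc([N+](=O)[O-])cc2)c(N)c1/N=N/c1ccc(O)cc1`: > 25000 nM
Compound 3 `CCOC(=O)n1nc(N)c(/N=N/c2ccc(O)cc2)c1N`: > 100000 nM

In a functional assay on K562 cells (Homo sapiens) for cytotoxicity, read by fluorescence, with a stated time of 72 h (a higher number here means a weaker inhibitor, a lower number a stronger inhibitor), compound 3 gives only a limit, > 100000 nM, and not a true number. Compound 2 also gives only a limit, > 25000 nM. Compound 1 alone has a true number, 17000 nM.

Compound 4 `Nc1n[nH]c(N)c1/N=N/c1ccc(O)cc1` has hydrogen in place of ethoxycarbonyl on an aromatic nitrogen. Among the measured compounds shown here, the one measured step at this nitrogen, a step that the two limits leave unreadable from compound 2 to compound 3, joins two limits, so it offers no size to carry over. Compound 1 also carries hydrogen on that nitrogen and gives 17000 nM, so a shift towards stronger inhibition in this assay is expected, although this rests on a single compound. The estimated change is an at least 3.3-fold lower number from compound 3 to compound 4 (0.52 log units; beyond the scatter). Compound 4 is expected at 30000 nM, with an estimated range from 9000 nM to 100000 nM.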

Compound 4, half-maximal inhibitory concentration: 33000 nM
Compound 4: the middle estimate sits 1.1-fold (0.04 log units) below what was measured, and the stated range covers the measured number.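

Removing the ethoxycarbonyl group gives an at least 3.0-fold lower number from compound 3 to compound 4 (0.48 log units; beyond the scatter) in this assay, the first readable size for a change on this aromatic nitrogen; the earlier step there joins two limits and cannot be read. Compound 4 joins compound 1 as a second compound with hydrogen on this nitrogen and a true number, whereas the two compounds shown with a carbonyl group on it give only limits. The real size of the step may be larger, because compound 3 gives only a limit and not a number: the limit of > 100000 nM in this assay, at which 1 of the 4 values shown sits.

On these data alone, whether a methyl group or a longer chain on this nitrogen would keep a true number stays open. So does whether an amine or a carboxylic acid carried on such a chain would shift the number in either direction.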